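The compounds below may be only part of what the source reports. "The series", "measured", "known", "first", "only" and "open" are said of these compounds alone.

Measured so far:
Compound 1 `CNC(=O)/C=C/c1ccc(NC(=O)Nc2ccc(Cl)c(C(F)(F)F)c2)cc1`: 20900 nM
Compound 2 `CC1CN(C(=O)/C=C/c2ccc(NC(=O)Nc3ccc(Cl)c(C(F)(F)F)c3)cc2)CC(C)O1`: > 50000 nM

For the measured compounds named here, in a functional assay on A-375 cells (Homo sapiens) for inhibition, read by MTT assay, with a stated time of 120 h (a lower number here means a stronger inhibitor, a higher number a weaker inhibitor), compound 1 gives 20900 nM, the only true number so far. Compound 2 gives > 50000 nM, which is a limit of the assay and not a number. That makes compound 1 the stronger of the two, by an at least 2.3-fold higher number from compound 1 to compound 2 (0.37 log units; beyond the scatter).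

Compound 3 `CNC(=O)CCc1ccc(NC(=O)Nc2ccc(Cl)c(C(F)(F)F)c2)cc1` has not yet been measured. It carries 2-(methylcarbamoyl)ethyl in place of the 2-(methylcarbamoyl)ethenyl of compound 1, on an aromatic carbon, para to a large group (2-(methylcarbamoyl)ethyl in place of 2-(methylcarbamoyl)ethenyl on an aromatic carbon). Going by the values given here, the one measured step, an at least 2.3-fold higher number from compound 1 to compound 2 (0.37 log units; beyond the scatter), alters the group on the carbonyl carbon and leaves this chain otherwise untouched, so it offers only weak guidance here. No step beyond the scatter is therefore expected in this assay. The estimated change is a 1.2-fold higher number from compound 1 to compound 3 (0.08 log units; within the scatter). For compound 3 the expected value is 25000 nM, with an estimated range of 10000 nM to 50000 nM.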

Compound 3, half-maximal inhibitory concentration: 25200 nM
For compound 3 the middle estimate is 1.0-fold (0.00 log units) below the measured one; low and high end bracket the measured number.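

In this assay, replacing 2-(methylcarbamoyl)ethenyl with 2-(methylcarbamoyl)ethyl on the aromatic carbon removes one double bond outside the aromatic ring and leaves the heavy-atom count unchanged, and the outcome is a 1.2-fold higher number from compound 1 to compound 3 (0.08 log units; within the scatter). At this position, then, the chain's double bond can be saturated without a change that can be told apart from the scatter in this assay. The earlier pair changed only the group on the carbonyl carbon, so it showed nothing about this part of the chain.

Still open, from the compounds shown here alone, is whether a longer chain, or a carboxylic acid at the chain's end, would shift the number beyond the scatter. Also open is how the 2,6-dimethylmorpholin-4-yl group behaves on the saturated chain, and the value of compound 2 remains a limit and not a number: the limit of > 50000 nM in this assay, at which 1 of the 3 values shown sits.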